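The source may report more compounds than this note shows. Statements on the series, on what has been measured and on what is new or still open speak of the compounds shown alone.

The measured compounds:
compound 1 `O=[N+]([O-])c1cccc(-c2nn(-c3ccccc3)cc2C(Nc2nc3ccccc3s2)c2c(O)ccc3ccccc23)c1`, 43900 nM;
compound 2 `Oc1ccc2ccccc2c1C(Nc1nc2ccccc2s1)c1cn(-c2ccccc2)nc1-c1ccccc1`, 48900 nM;
compound 3 `Oc1ccc2ccccc2c1C(Nc1nc2ccccc2s1)c1cn(-c2ccccc2)nc1-c1ccc(I)cc1`, 18900 nM.

In a functional assay on MCF7 cells (Homo sapiens) for antiproliferative activity, read by MTT assay, with a stated time of 48 h (on this read-out higher numbers stand for weaker inhibition and lower numbers for stronger inhibition), compound 2 holds the highest number of the three. The step from compound 1 to compound 2 is a 1.1-fold higher number from compound 1 to compound 2 (0.05 log units; within the scatter), which stays within the scatter, whereas a 2.6-fold lower number from compound 2 to compound 3 (0.41 log units; beyond the scatter) and a 2.3-fold lower number from compound 1 to compound 3 (0.37 log units; beyond the scatter) lie beyond it. Compound 4 `COc1ccc2nc(NC(c3cn(-c4ccccc4)nc3-c3ccccc3)c3c(O)ccc4ccccc34)sc2c1` differs from compound 2 by methoxy in place of hydrogen on an aromatic carbon. For the measured compounds named here, none of the measured steps touches this part of the molecule: all three alter the other aromatic ring. Going by the values given here, with no step bearing on the change, no shift beyond the scatter is expected, so the estimated step is a 1.0-fold lower number from compound 2 to compound 4 (0.01 log units; within the scatter). Compound 4 is therefore expected at about 48000 nM, within a range of 18000 nM to 120000 nM.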

Compound 4, half-maximal inhibitory concentration: 40800 nM
The estimate for compound 4 lay 1.2-fold (0.07 log units) above the measured number; measured number inside the range.
By their numbers in this assay, from the lowest: compound 3; then compounds 4, 1 and 2 (each within the scatter of the next).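

Moving from 1,3-benzothiazol-2-yl to 6-methoxy-1,3-benzothiazol-2-yl gives a 1.2-fold lower number from compound 2 to compound 4 (0.08 log units; within the scatter) in this assay. For the compounds shown here, this is the first reading at this part of the molecule, and it shows that methoxy in place of hydrogen here is tolerated, with no shift beyond the scatter. No supporting measurement is available to account for this result. On these data alone, whether an amine or a carboxylic acid at this position would behave the same remains open, as does whether methoxy here would give a similar result alongside the 4-iodophenyl group of compound 3.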